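Replacing a Pyridinyl Ring with Cyclohexenyl in VCaP Antiproliferation

The source may hold more compounds than are shown below. What is called first, only, known or untested is meant among the compounds shown, and "the series" means these compounds.

Measured compounds:
Compound 2, `CCN(c1ccc(C#N)c(Cl)c1)c1cc(-c2cccnc2)ccc1C`, 1270 nM
Compound 3, `Cn1nccc1-c1cccc2c1CCCN2c1ccc(C#N)c(C(F)(F)F)c1`, > 30000 nM
Compound 1, `CCN(c1cccc(-c2ccccc2)c1)c1ccc(C#N)c(Cl)c1`, "not determined" (no result reported)

Three compounds share the same aryl nitrile motif, but only one of them carries a number in a functional assay on VCaP cells (Homo sapiens) for antiproliferative activity, read by CCK-8 assay, with a stated time of 6 days; a higher number here means a weaker inhibitor, a lower number a stronger inhibitor. Going by the values given here, compound 2 gives 1270 nM, and this is the only single value available. Compound 3 reaches only a limit of the assay, > 30000 nM, so no number is known for it; the limit of > 30000 nM in this assay, at which 1 of the 3 values shown sits, marks where that limit sits. For compound 1 the entry reads "not determined" (no result reported), so compound 2 cannot be ranked against either neighbour.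

Compound 4, `CCN(c1ccc(C#N)c(Cl)c1)c1cc(C2=CCCCC2)ccc1C`, is the next compound to be tested in this assay. It differs from compound 2 in one place: cyclohex-1-en-1-yl in place of pyridin-3-yl on an aromatic carbon. Among the compounds with values here, no step between two measured compounds maps this kind of exchange, so the expectation rests on compound 2 alone. A change of this size at an aromatic carbon of the core is expected to move potency by a modest amount, most likely toward weaker inhibition, though a result within the scatter would not be surprising. Compound 4 is therefore estimated at 2200 nM, with a plausible range from 700 nM to 8000 nM, which corresponds to an expected step of a 1.7-fold higher number from compound 2 to compound 4 (0.24 log units; within the scatter).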

Compound 4, half-maximal inhibitory concentration: 20000 nM
For compound 4 the middle estimate is 9.1-fold (0.96 log units) below the measured one; measured number above the stated range.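

In this assay, cyclohex-1-en-1-yl in place of pyridin-3-yl gives a 16-fold higher number from compound 2 to compound 4 (1.20 log units; beyond the scatter), which shows that this aromatic carbon, meta to a large group and para to a methyl group, is sensitive to the group it carries. The exchange keeps a six-membered ring and the absence of net charge, yet it removes both the ring nitrogen with its hydrogen-bond acceptor and the aromatic character of the ring, so the pair shows that ring size alone does not preserve the activity of compound 2 but cannot separate these two differences. Compound 4 still reads as a number and not as a limit, whereas the one limit among these compounds belongs to compound 3: the limit of > 30000 nM in this assay, at which 1 of the 4 values shown sits.

The compounds shown leave open whether the loss follows the ring nitrogen or the aromatic ring, since a plain phenyl on the core of compound 2 would keep the aromatic ring without that nitrogen, while a piperidine would keep a ring nitrogen without aromatic character. They also leave open whether a pyrimidine or a pyridine joined through another ring carbon would give a lower number than compound 2.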